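Swapping the ketone side group in a glutamate receptor modulator

The compounds below may be only part of what the source reports. "The series", "measured", "known", "first", "only" and "open" are said of these compounds alone.

Two compounds have been measured in an assay on HEK293 cells for positive allosteric modulation of metabotropic glutamate receptor 3 (Rattus norvegicus), read by thallium flux, with a stated time of 2.5 min; a higher number here means a larger maximal response, a lower number a smaller maximal response:

compound 1 `Cc1c(OCCCCOc2ccc(C(=O)O)cc2Cl)ccc(C(=O)CC2CCCC2)c1O` gives 27.4%
compound 2 `COc1ccc(C(=O)O)cc1OCCCCOc1ccc(C(=O)C(C)C)c(O)c1C` gives 59.9%

Compound 2 gives the higher of the two numbers, and its gap to compound 1 lies beyond the usual scatter. The two compounds differ in more than one place, so the gap cannot be pinned on a single change. Compound 3 `COc1ccc(C(=O)O)cc1OCCCCOc1ccc(C(=O)CC2CCCC2)c(O)c1C` keeps the core of compound 2 and alters only the group on the carbonyl carbon: cyclopentylmethyl in place of isopropyl on a carbonyl carbon. A cyclopentylmethyl group on the carbonyl carbon is also found in compound 1, which gives the smaller response, though compound 1 carries further differences as well. On this basis a downward step of moderate size in this assay is expected for compound 3, with wide uncertainty. The expected step is a number 14.9 percentage points lower from compound 2 to compound 3 (beyond the scatter). Compound 3 is thus estimated at 45%, within a range from 25% to 68%.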

Compound 3, largest response reached (reported as percent of maximum), in percent of the reference or control that the assay uses: 67.6%
Compound 3: the middle estimate sits 22.6 percentage points below what was measured; measured number inside the range.
By their numbers in this assay, from the lowest: compound 1; then compounds 2 and 3 (each within the scatter of the next).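

In this assay, putting cyclopentylmethyl in place of isopropyl on the carbonyl carbon gives a number 7.7 percentage points higher from compound 2 to compound 3 (within the scatter), so on this core the two groups cannot be told apart. The earlier gap therefore does not follow the cyclopentylmethyl group: with that group present in both compounds, 5-carboxy-2-methoxyphenyl in place of 4-carboxy-2-chlorophenyl on an oxygen on a saturated carbon gives a number 40.2 percentage points higher from compound 1 to compound 3 (beyond the scatter), a large step that points to this end of the molecule instead. No available evidence explains either result.

The compounds shown leave open how far the group on the carbonyl carbon can vary, for instance to a longer unbranched chain such as hexyl or to a benzyl group. They also leave open which part of the swapped end carries the large step: the methoxy group, the chlorine, or the placing of the carboxylic acid.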